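A few compounds are considered here, and "the series" means these few. Any claim that something is new, unique, unknown or untested is made for them only; others in the source may bear on it.

Three compounds have been measured so far:
compound 1 `O=Cc1ccc(-c2cn3ccnc3c(-c3ccc4ncn(C5CCCCC5)c4c3)n2)cc1` gives 25.3% in a functional assay on NCI-H522 cells (Homo sapiens) for inhibition, read by sulforhodamine B assay, with a stated time of 48 h, tested at 10 uM; a lower number here means less inhibition, a higher number more inhibition at the concentration tested (going by the name of the read-out);
compound 2 `Fc1ccc(-c2cn3ccnc3c(-c3ccc4ncn(C5CCCCC5)c4c3)n2)cc1` gives 15.5%;
compound 3 `Clc1ccc(-c2cn3ccnc3c(-c3ccc4ncn(C5CCCCC5)c4c3)n2)cc1` gives 19.8%.

Compound 3 stands second highest of these three numbers, yet both steps leading to it, a number 4.3 percentage points higher from compound 2 to compound 3 (within the scatter) and a number 5.5 percentage points lower from compound 1 to compound 3 (within the scatter), lie within the scatter, so the three compounds cannot be told apart on these values. Compound 4 `COc1ccccc1-c1cn2ccnc2c(-c2ccc3ncn(C4CCCCC4)c3c2)n1` differs from compound 3 in one place: 2-methoxyphenyl in place of 4-chlorophenyl on an aromatic carbon. The measured steps that exchange one group at this same position, a number 9.8 percentage points lower from compound 1 to compound 2 (within the scatter), a number 5.5 percentage points lower from compound 1 to compound 3 (within the scatter) and a number 4.3 percentage points higher from compound 2 to compound 3 (within the scatter), all fall within the scatter, so no step beyond the scatter is expected in this assay for compound 4. Compound 4 is therefore estimated at 20%, with a range from 7% to 35%. This corresponds to an expected step of a number 0.2 percentage points higher from compound 3 to compound 4 (within the scatter).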

Compound 4, a percentage reported as inhibition, at one concentration (the size of the read-out at that concentration, not a potency): 22.2%
For compound 4 the middle estimate is 2.2 percentage points below the measured one, within the range that was stated.
By their numbers in this assay, from the lowest: compounds 2, 3, 4 and 1 (each within the scatter of the next).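

In this assay the steps to the 2-methoxyphenyl group, a number 2.4 percentage points higher from compound 3 to compound 4 (within the scatter) and a number 6.7 percentage points higher from compound 2 to compound 4 (within the scatter) and a number 3.1 percentage points lower from compound 1 to compound 4 (within the scatter) all lie within the scatter. This position therefore also accepts a phenyl ring with a methoxy group at a different ring carbon, and 2-methoxyphenyl cannot be told apart from 4-chlorophenyl, 4-fluorophenyl or 4-formylphenyl. No measurement at hand offers an explanation for this result. Still open, on these data alone, is whether a phenyl ring carrying an amine or a carboxylic acid would give a step beyond the scatter. The same question stands for a longer chain at this position.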